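Adding a Methyl to Compound 3

The compounds below may be only part of what the source reports. "The series", "measured", "known", "first", "only" and "open" are said of these compounds alone.

Compound 3 `CC1=NN(c2ccc(Cl)cc2)C(=O)C12C=CC(=O)C=C2c1ccccc1` sits at the edge of a functional assay on A549 cells (Homo sapiens) for antiproliferative activity, read by CCK-8 assay, with a stated time of 72 h; a lower number here means a stronger inhibitor, a higher number a weaker inhibitor; for compound 3 the value > 100000 nM is a limit of the assay, not a number. The compounds with numbers are compound 1 `CC1=NN(c2ccc(C)cc2)C(=O)C12C=CC(=O)C=C2c1cccc(C)c1`, which in this assay gives 22500 nM, and compound 2 `CC1=NN(c2cccc(Cl)c2)C(=O)C12C=CC(=O)C=C2c1ccccc1`, which gives 18800 nM. Going by the values given here, the one measured step, an at least 5.3-fold higher number from compound 2 to compound 3 (0.72 log units; beyond the scatter), ends at the limit (the limit of > 100000 nM in this assay, at which 1 of the 3 values shown sits). Among the compounds with values here, compound 4 `CC1=NN(c2ccc(Cl)cc2)C(=O)C12C=CC(=O)C=C2c1cccc(C)c1` differs from compound 3 by methyl in place of hydrogen on an aromatic carbon; no measured step covers this methyl-for-hydrogen change. Compound 1 shows that a 3-methylphenyl is compatible with measurable inhibition when the nitrogen bears 4-methylphenyl rather than 4-chlorophenyl. Compound 4 is therefore expected to remain weak, with a step of an at least 1.1-fold lower number from compound 3 to compound 4 (0.04 log units; that floor lies within the scatter) expected to be small, giving an estimated 90000 nM between 30000 nM and 250000 nM.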

Compound 4, half-maximal inhibitory concentration: 38400 nM
Estimate against measurement, compound 4: 2.3-fold (0.37 log units) above; measured number inside the range.
By their numbers in this assay, from the lowest: compounds 2, 1 and 4 (each within the scatter of the next, the first and the last beyond it). At a limit, above all of these: compound 3.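

In this assay the change from phenyl to 3-methylphenyl gives an at least 2.6-fold lower number from compound 3 to compound 4 (0.41 log units; beyond the scatter) in the 4-chlorophenyl series, so this methyl turns a limit into a measured number. That step is only a floor, as its starting point is a limit: the limit of > 100000 nM in this assay, at which 1 of the 4 values shown sits. With 3-methylphenyl in place, the nitrogen substituent matters little, as a 1.7-fold higher number from compound 1 to compound 4 (0.23 log units; within the scatter) stays within the scatter.

As far as these compounds go, it remains open whether this methyl would have a similar effect alongside the 3-chlorophenyl of compound 2. From the compounds shown here alone, it is also open whether a methoxy, an amine or a longer chain on that aromatic carbon would give a lower number.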